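The source may hold more compounds than are shown below. What is called first, only, known or untested is meant among the compounds shown, and "the series" means these compounds.

Among the compounds with values here, in an ADME assay on MT4 cells (Homo sapiens) for cytotoxicity, read by MTT assay (a lower number here means that less compound is tolerated, a higher number that more compound is tolerated), two compounds have numbers so far. Compound 1 `COC(=O)c1ccc(NC(=O)CSc2nncnc2-c2cccc3ccccc23)c(Br)c1` gives 173000 nM, and compound 2 `O=C(CSc1nncnc1-c1cccc2ccccc12)Nc1ccccc1` gives 154000 nM. These two values lie within the usual scatter of each other, so compound 2 stands level with compound 1.

Compound 3 `O=C(CSc1nncnc1-c1cccc2ccccc12)Nc1ccccc1Br` is compound 2 with a single change: bromo in place of hydrogen on an aromatic carbon. Put simply, this is bromo in place of hydrogen on an aromatic carbon, turning the phenyl into a 2-bromophenyl. Within the data shown here, no measured pair shows this change on its own, so the data give no direct size for it.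

With only compound 2 at 154000 nM as the anchor, no shift beyond the scatter is expected in this assay. The expected change is a 1.1-fold lower number from compound 2 to compound 3 (0.06 log units; within the scatter). For compound 3, the estimated value is 135000 nM, with an expected range of 50000 nM to 260000 nM.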

Compound 3, half-maximal cytotoxic concentration: 87000 nM
The estimate for compound 3 lay 1.6-fold (0.19 log units) above the measured number; measured number inside the range.
By their numbers in this assay, from the lowest: compounds 3, 2 and 1 (each within the scatter of the next).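

Putting bromo on the phenyl of compound 2 now has a measured size in this assay, and that size is a 1.8-fold lower number from compound 2 to compound 3 (0.25 log units; within the scatter). Removing the methoxycarbonyl from compound 1 while keeping its bromo gives a 2.0-fold lower number from compound 1 to compound 3 (0.30 log units; within the scatter), so neither single change moves the number beyond the scatter. Nothing measured here offers a cause for these small steps.

The compounds shown carry only hydrogen or bromo on this aromatic carbon, so it remains open whether a different group there, such as an amine or a carboxylic acid, would shift the number beyond the scatter. On these data alone, it also remains open whether a methoxycarbonyl on the phenyl of compound 2, without any bromo, would leave the number within the scatter.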